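Compound 3 to compound 4: a larger chain end

The source may report more compounds than this note shows. Statements on the series, on what has been measured and on what is new or still open speak of the compounds shown alone.

Of the compounds shown here, three on the shared core have been measured: compound 1 `CN(C)CCCCCn1c2c(c3ccccc31)C(=O)c1c[n+]([O-])c3ccccc3c1C2=O`, compound 2 `O=C1c2c[n+]([O-])c3ccccc3c2C(=O)c2c1c1ccccc1n2CCCCn1ccnc1` and compound 3 `CN(C)CCCCn1c2c(c3ccccc31)C(=O)c1c[n+]([O-])c3ccccc3c1C2=O`. In a functional assay on A549 cells (Homo sapiens) for cytotoxicity, read by MTT assay, with a stated time of 72 h (on this read-out lower numbers stand for stronger inhibition and higher numbers for weaker inhibition), compound 1 gives 210 nM, compound 2 gives 170 nM and compound 3 gives 310 nM, which places compound 3 within the scatter of both others. Compound 4 `CN1CCN(CCCCCn2c3c(c4ccccc42)C(=O)c2c[n+]([O-])c4ccccc4c2C3=O)CC1` differs from compound 3 by (4-methylpiperazin-1-yl)methyl in place of dimethylamino on a saturated chain carbon, four bonds along the chain from an aromatic nitrogen, on a saturated chain carbon, four bonds along the chain from an aromatic nitrogen. Two measured steps at this place bear on it: a 1.5-fold higher number from compound 1 to compound 3 (0.17 log units; within the scatter) and a 1.8-fold higher number from compound 2 to compound 3 (0.26 log units; within the scatter), both within the scatter. Within the data shown here, no measured compound carries the (4-methylpiperazin-1-yl)methyl group. No step beyond the scatter is therefore expected in this assay. The expected step is a 1.4-fold lower number from compound 3 to compound 4 (0.15 log units; within the scatter). Compound 4 is estimated at 220 nM, with an expected range of 100 nM to 500 nM.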

Compound 4, half-maximal inhibitory concentration: 870 nM
Estimate against measurement, compound 4: 4.0-fold (0.60 log units) below, outside the stated range (above it).
By their numbers in this assay, from the lowest: compounds 2, 1 and 3 (each within the scatter of the next); then compound 4.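

In this assay, among these compounds, this chain end gives the first steps beyond the scatter: a 2.8-fold higher number from compound 3 to compound 4 (0.45 log units; beyond the scatter), a 5.1-fold higher number from compound 2 to compound 4 (0.71 log units; beyond the scatter) and, with the chain unchanged, a 4.1-fold higher number from compound 1 to compound 4 (0.62 log units; beyond the scatter). The dimethylamino and 1H-imidazol-1-yl ends stay within the scatter of one another, so the 4-methylpiperazin-1-yl end alone stands apart. Nothing at hand explains this step.

As far as these compounds go, whether the ring itself or its second nitrogen goes with the weaker number stays open. A piperidine or morpholine end on the same chain would separate the two.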